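A few compounds are considered here, and "the series" means these few. Any claim that something is new, unique, unknown or untested is made for them only; others in the source may bear on it.

For the measured compounds named here, in a functional assay on MDA-MB-468 cells (Homo sapiens) for antiproliferative activity, read by MTT assay, with a stated time of 72 h (a higher number here means a weaker inhibitor, a lower number a stronger inhibitor), compound 1 `COc1cc(-c2nccn2-c2cccc3ccccc23)cc(OC)c1OC` gives 6200 nM and compound 3 `COc1ccc(C(=O)Nc2cc(OC)c(OC)c(OC)c2)cc1[N+](=O)[O-]` gives 3000 nM as the lowest number so far, a gap beyond the scatter. Compound 2 `COc1ccc(OC(=O)c2cc(OC)c(OC)c(OC)c2)cc1N` reads > 100000 nM as a limit of the assay and not a number.

Going by the values given here, the next step leads to compound 4 `COc1ccc(C(=O)Nc2cc(OC)c(OC)c(OC)c2)cc1N` with amino in place of nitro on an aromatic carbon, ortho to a methoxy group and meta to a large group amino in place of nitro on an aromatic carbon as the only change from compound 3. Among the compounds with values here, no measured pair isolates this change, so its size in this assay has no direct precedent. Compound 4 shares the amino group with compound 2, whose reading stays a limit at > 100000 nM but whose link differs, and this leaves a wide margin toward weaker readings. The expected step of a 1.2-fold lower number from compound 3 to compound 4 (0.08 log units; within the scatter) stays within the scatter, with compound 3 at 3000 nM as the anchor. The estimate for compound 4 is 2500 nM with an expected range of 250 nM to 30000 nM in this series.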

Compound 4, half-maximal inhibitory concentration: > 100000 nM
Compound 4 gave a limit, no number; the forecaster's own chance of this, stated with the estimate: 10%; at least 40-fold (1.60 log units) between middle value and limit.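

In this assay, for the compounds shown here, this aromatic carbon, ortho to a methoxy group and meta to a large group, proves highly sensitive to its substituent: amino in place of nitro gives an at least 33-fold higher number from compound 3 to compound 4 (1.52 log units; beyond the scatter), the first single-place change. Compound 4 reads > 100000 nM, a limit of the assay and not a number, so the size of this step is only a lower bound. The amino group is present in both compounds at this limit, compound 2 and compound 4, although their links differ: the limit of > 100000 nM in this assay, at which 2 of the 4 values shown sit.

The compounds shown do not settle whether the large step reflects the loss of nitro or the arrival of amino. Hydroxyl, methyl or acetamide at the same carbon would help separate these two readings.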